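Compound 3 to compound 4: an exchange on the amide nitrogen

A few compounds are considered here, and "the series" means these few. Any claim that something is new, unique, unknown or untested is made for them only; others in the source may bear on it.

In a functional assay on MDA-MB-435 cells (Homo sapiens) for cytotoxicity, read by MTT assay, with a stated time of 72 h (a lower number here means a stronger inhibitor, a higher number a weaker inhibitor), compound 1 `CN(C)CCCNc1c(C(=O)NCc2ccc(F)cc2)nc(Br)c2cccnc12` gives 7000 nM and compound 2 `N[C@H]1CC[C@H](Nc2c(C(=O)NCc3ccc(F)cc3)nc(Br)c3cccnc23)CC1` gives 6000 nM. The step between them, a 1.2-fold lower number from compound 1 to compound 2 (0.07 log units; within the scatter), is within the scatter.

Compound 3 `C[C@H](NC(=O)c1nc(Br)c2cccnc2c1N[C@H]1CC[C@H](N)CC1)c1ccc(F)cc1` gives > 10000 nM, which is a limit of the assay and not a number. Its standing in the series therefore rests only on (the limit of > 10000 nM in this assay, at which 1 of the 3 values shown sits).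

The next change, ((thiophen-2-yl)methyl in place of 1-(4-fluorophenyl)ethyl on an amide-type nitrogen), puts (thiophen-2-yl)methyl in place of 1-(4-fluorophenyl)ethyl on an amide-type nitrogen and gives compound 4 `N[C@H]1CC[C@H](Nc2c(C(=O)NCc3cccs3)nc(Br)c3cccnc23)CC1`. This exchange also removes the methyl that entered in an at least 1.6-fold higher number from compound 2 to compound 3 (0.22 log units; that floor lies within the scatter). That step offers only a floor within the scatter, so it gives weak support for a move toward a lower number. Among the compounds with values here, no measured step covers the exchange of the ring itself, and a 1.2-fold lower number from compound 1 to compound 2 (0.07 log units; within the scatter) concerns a different part of the structure.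

Only a small step is therefore expected in this assay, toward a lower number, with compound 4 staying weak and possibly reaching the limit. The estimated step is an at least 1.6-fold lower number from compound 3 to compound 4 (0.22 log units; that floor lies within the scatter). For compound 4 the expected value is 6000 nM, with an estimated range of 2500 nM to 14000 nM.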

Compound 4, half-maximal inhibitory concentration: 4100 nM
Compound 4: the middle estimate sits 1.5-fold (0.17 log units) above what was measured, within the range that was stated.
By their numbers in this assay, from the lowest: compounds 4, 2 and 1 (each within the scatter of the next). At a limit, above all of these: compound 3.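

Within the data shown here, on the amide nitrogen, the exchange of 1-(4-fluorophenyl)ethyl for (thiophen-2-yl)methyl gives, in this assay, an at least 2.4-fold lower number from compound 3 to compound 4 (0.38 log units; beyond the scatter), the first step at this position that clears the scatter. That step starts from a limit of the assay and not a number: the limit of > 10000 nM in this assay, at which 1 of the 4 values shown sits.

The exchange of the ring alone, with no methyl involved, gives a 1.5-fold lower number from compound 2 to compound 4 (0.17 log units; within the scatter), so 4-fluorophenyl and thiophen-2-yl on the saturated chain carbon are not told apart here, and what clears the scatter in the step from compound 3 cannot be assigned to the ring.

On these data alone, it remains open whether an aromatic ring on the amide nitrogen matters at all, a question that a cyclohexylmethyl group in place of (thiophen-2-yl)methyl would address against compound 4 at 4100 nM. Also open, as far as these compounds go, is whether a carboxylic acid on the chain in place of the 3-(dimethylamino)propyl amine of compound 1, or any other change on that nitrogen on the aromatic ring, would move the number in this assay.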